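Changing the Side Chain of Compound 2

The source may report more compounds than this note shows. Statements on the series, on what has been measured and on what is new or still open speak of the compounds shown alone.

In an ADME assay on the whole organism (Rattus norvegicus, strain Sprague-Dawley) for pharmacokinetics, at a dose of 10 mg/kg by the oral route (a lower number here means less compound in the circulation, a higher number more compound in the circulation at the dose given), compound 1 `CCC(CC)N(CCN(C)C(=O)CCC(=O)O)Cc1cccc(C(=O)Nc2sc3c(c2C(=O)c2cnn(-c4ccc(Cl)c(C(F)(F)F)c4)c2)CCC(C)(C)C3)c1` gives 767 nM and compound 2 `CCC(CC)N(CCN(C)C(=O)CCC(=O)NCCOCCOCCOCCO)Cc1cccc(C(=O)Nc2sc3c(c2C(=O)c2cnn(-c4ccc(Cl)c(C(F)(F)F)c4)c2)CCC(C)(C)C3)c1` gives 28.4 nM as the lower of the two numbers, a gap beyond the scatter. Compound 3 `CCC(CC)N(CCN(C)C(=O)CCC(=O)NC(C)(C)C(=O)NCCN(C)C)Cc1cccc(C(=O)Nc2sc3c(c2C(=O)c2cnn(-c4ccc(Cl)c(C(F)(F)F)c4)c2)CCC(C)(C)C3)c1` differs from compound 2 on an amide-type nitrogen a group of 11 heavy atoms (8 carbon, 2 nitrogen, 1 oxygen; no ring) in place of a group of 12 heavy atoms (8 carbon, 4 oxygen; no ring), on an amide-type nitrogen by carrying a 1-((2-(dimethylamino)ethyl)carbamoyl)-1-methylethyl group. Among the measured compounds shown here, no measured pair shows a single change of this kind, so the forecast is uncertain. In this assay the expected step of a 1.4-fold higher number from compound 2 to compound 3 (0.15 log units; within the scatter) is small, upward and within the scatter. Compound 3 is estimated at 40 nM (expected range 10 nM to 160 nM).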

Compound 3, maximal plasma concentration in the Rattus norvegicus assay: 15.8 nM
For compound 3 the middle estimate is 2.5-fold (0.40 log units) above the measured one, within the range that was stated.
By their numbers in the Rattus norvegicus assay, from the lowest: compounds 3 and 2 (each within the scatter of the next); then compound 1.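

In the Rattus norvegicus assay, placing 1-((2-(dimethylamino)ethyl)carbamoyl)-1-methylethyl on the amide-type nitrogen gives a 1.8-fold lower number from compound 2 to compound 3 (0.25 log units; within the scatter), so two quite different chains here cannot be told apart by this read-out. Putting that amino group in place of hydroxy on the carbonyl carbon gives a 49-fold lower number from compound 1 to compound 3 (1.69 log units; beyond the scatter), so the large gap from the free acid is seen with both amides. In a physicochemical assay for solubility, in simulated intestinal fluid, at pH 6.6 (a higher number here means a more soluble compound, a lower number a less soluble compound), compound 2 gives 107 ug/mL and compound 3 gives 242 ug/mL. Solubility does separate the two amides: the measured solubility of compound 2, 107 ug/mL, and of compound 3, 242 ug/mL, a 2.3-fold higher number (0.35 log units; beyond the scatter)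

From the compounds shown here alone, whether a chain ending in a carboxylic acid on this amide-type nitrogen would come closer to compound 1 remains open.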